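Moving fluorine on the phenyl group at the assay limit

A few compounds are considered here, and "the series" means these few. Any claim that something is new, unique, unknown or untested is made for them only; others in the source may bear on it.

Compound 1 `O=C(Nc1ccc2sc(-c3cccc(F)c3)nc2c1)N1CCCCC1` gives > 50000 nM as a limit
Compound 2 `O=C(Nc1ccc2sc(-c3ccc(F)c(F)c3)nc2c1)N1CCC(F)CC1` gives > 50000 nM as a limit
Compound 3 `O=C(Nc1ccc2sc(-c3ccc(F)c(F)c3)nc2c1)N1CCCC1` gives > 50000 nM as a limit

In an ADME assay on HepG2 cells (Homo sapiens) for inhibition, read by resazurin assay, with a stated time of 48 h (on this read-out lower numbers stand for an effect already at smaller amounts and higher numbers for an effect only at larger amounts of compound), compound 1 stands at > 50000 nM which is a limit and not a number. It sits with the others at the limit of > 50000 nM in this assay, at which 3 of the 3 values shown sit, so no order among them can be read.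

Compound 4 `O=C(Nc1ccc2sc(-c3ccc(F)cc3)nc2c1)N1CCCCC1` differs from compound 1 by 4-fluorophenyl in place of 3-fluorophenyl on an aromatic carbon and keeps the same atoms, joined differently. Among the measured compounds shown here, the one measured step, a step that the two limits leave unreadable from compound 2 to compound 3 lies on a carbonyl carbon and gives no size to carry over.

Since compound 1 gives > 50000 nM as a limit, no step beyond the scatter is expected in this assay for compound 4. The expected outcome is a number no higher from compound 1 to compound 4 (the limit leaves the size open) and nothing larger. For compound 4 the estimate is 50000 nM with an expected range from 25000 nM to 100000 nM in this read-out.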

Compound 4, half-maximal effective concentration: > 50000 nM
Compound 4: no number, only a limit (the forecaster's own chance of this, stated with the estimate: 85%); the middle value lies on the limit itself.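

In this assay, among the compounds shown here, compound 4 gives > 50000 nM as a limit and not a number, so no step from compound 1 to compound 4 can be read. The compounds shown leave open whether 4-fluorophenyl and 3-fluorophenyl differ at all, and how any of the compounds rank, since all share one limit: the limit of > 50000 nM in this assay, at which 4 of the 4 values shown sit.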